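The compounds below may be only part of what the source reports. "The series", "measured", "known", "first", "only" and "open" are said of these compounds alone.

In a physicochemical assay for permeability, using PAMPA (a lower number here means that the compound crosses the layer more slowly, a higher number that the compound crosses the layer faster), compound 2, `C[C@@H](Oc1cc2oc(=O)n(CCC(=O)O)c2cc1Cl)c1cccnn1`, gives < 3 nm/s, which is a limit of the assay and not a number. Compound 3, `COc1cc2oc(=O)n(CCC(=O)O)c2cc1Cl`, gives < 3 nm/s, which is also a limit. Only compound 1, `O=C(O)CCn1c(=O)oc2cc(OCC3CCC3)c(Cl)cc21`, gives a real number, at 12 nm/s. This leaves compound 2 with an at least 4.0-fold lower number from compound 1 to compound 2 (0.60 log units; beyond the scatter), and compound 3 shows an at least 4.0-fold lower number from compound 1 to compound 3 (0.60 log units; beyond the scatter). From the compounds shown here alone, both steps lie beyond the scatter, but their true size stays open, as both rest on (the limit of < 3 nm/s in this assay, at which 2 of the 3 values shown sit).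

Compound 4, `Cc1ccnc([C@@H](C)Oc2cc3oc(=O)n(CCC(=O)O)c3cc2Cl)c1`, swaps only the ring on the saturated chain carbon: 4-methylpyridin-2-yl in place of pyridazin-3-yl on a saturated chain carbon bound to an oxygen on an aromatic ring and a saturated chain carbon. For the measured compounds named here, no measured step covers this exact swap. The entering group holds more carbon than the one it replaces, a small move towards the carbon-only group of compound 1 with its 12 nm/s, so a modest rise in this assay is expected. The expected step is an at least 1.6-fold higher number from compound 2 to compound 4 (0.22 log units; that floor lies within the scatter), and it may remain hidden at the limit. The estimate for compound 4 is 5 nm/s, with an expected range from 2 nm/s to 14 nm/s.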

Compound 4, apparent permeability: < 3 nm/s
Compound 4 gave a limit, no number; the forecaster's own chance of this, stated with the estimate: 35%; middle value at least 1.6-fold (0.22 log units) from the limit.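

In this assay compound 4 gives < 3 nm/s, which is a limit and not a number. Compound 2 also sits at a limit, so no step from compound 2 to compound 4 can be read: the limit of < 3 nm/s in this assay, at which 3 of the 4 values shown sit.

From the compounds shown here alone, whether 4-methylpyridin-2-yl in place of pyridazin-3-yl changes the read-out at all stays open.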